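Methyl on a Small Ring: Expected Lipophilicity of Compound 4

A few compounds are considered here, and "the series" means these few. Any claim that something is new, unique, unknown or untested is made for them only; others in the source may bear on it.

In a physicochemical assay for lipophilicity, read by HPLC (a lower number here means a more polar compound, a higher number a more lipophilic compound), compound 1 `C[C@@H]1CN(c2cnc(C#N)c(-c3cnn(C)c3)n2)CCN1C(=O)C1CC1` gives 1.8. Compound 2 `Cn1cc(-c2ncc(C#N)c(N3CCN(c4cccc(F)c4)CC3)n2)cn1` comes from a different branch of the same work; in this assay compound 2 gives 3.2. The difference between the cores of compound 1 and compound 2 is not broken down here; their two numbers simply show compound 2 as the more lipophilic of the pair. Compound 3 `C[C@@H]1CN(c2nc(-c3cnn(C)c3)ncc2C#N)CCN1c1cccc(F)c1` is compound 2 with methyl in place of hydrogen on a saturated ring carbon, and in this assay compound 3 gives 3.3. The resulting step is a number 0.10 log units higher from compound 2 to compound 3 (within the scatter).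

Compound 4 `C[C@@H]1C[C@H]1C(=O)N1CCN(c2cnc(C#N)c(-c3cnn(C)c3)n2)C[C@H]1C` has not yet been measured. It differs from compound 1 by methyl in place of hydrogen on a saturated ring carbon. Among the measured compounds shown here, this is the same kind of change as the one from compound 2 to compound 3, but not the same: there the methyl enters on a six-membered non-aromatic ring with 2 nitrogen, next to the ring nitrogen and next to the ring atom that bears a 3-fluorophenyl group, whereas here it enters on a three-membered non-aromatic ring of carbon only, next to the ring atom that bears a large group.

For the measured compounds named here, the one measured instance of this kind of change, a number 0.10 log units higher from compound 2 to compound 3 (within the scatter), stayed within the scatter, while the different place leaves room for a somewhat larger step. On that footing, compound 4 is expected to lie higher than its parent by a number 0.40 log units higher from compound 1 to compound 4 (beyond the scatter). In this assay compound 4 is therefore estimated at 2.2, most likely between 1.8 and 2.6.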

Compound 4, distribution coefficient: 1.6
The estimate for compound 4 lay 0.60 log units above the measured number, and the stated range ends above it.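

In this assay the new step is a number 0.20 log units lower from compound 1 to compound 4 (within the scatter), and the earlier step is a number 0.10 log units higher from compound 2 to compound 3 (within the scatter), so on both cores, methyl in place of hydrogen on a saturated ring carbon leaves the number within the usual scatter of repeated measurements. This does not show that the change carries over from one core to another as a rule, since the two pairs differ in where the methyl enters: on a six-membered non-aromatic ring with 2 nitrogen in compound 3, and on a three-membered non-aromatic ring of carbon only in compound 4, so no single site has been followed across both cores, and two pairs are too few to describe the whole series. Nothing shown here offers a reason for the size of either step.

The compounds shown leave open whether a group other than methyl on the cyclopropyl ring of compound 1, such as an ethyl group, an amine or a carboxylic acid, would move the number beyond the scatter. They also leave open whether the other spatial arrangement of 2-methylcyclopropyl would read like compound 4.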